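Fluoro for methoxy: a single-point change in the series

The source may report more compounds than this note shows. Statements on the series, on what has been measured and on what is new or still open speak of the compounds shown alone.

Going by the values given here, compound 1 `COc1ccc(-c2ccc(-c3ccc(C(=N)N)cc3)s2)cc1` is the only member of the series with a number in hand: in a functional assay on MDA-MB-231 cells (Homo sapiens) for inhibition, read by sulforhodamine B assay, with a stated time of 48 h (on this read-out lower numbers stand for stronger inhibition of growth and higher numbers for weaker inhibition of growth), compound 1 gives 267 nM. Compound 2 `N=C(N)c1ccc(-c2ccc(-c3cc(Cl)cc(Cl)c3)s2)cc1` belongs to the same series, but in this assay compound 2 gives "not determined" (no result reported), so it offers no comparison. Among the compounds with values here, no step between two measured compounds is available, and the scatter of the measurement itself is the only yardstick.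

Compound 3 `N=C(N)c1ccc(-c2ccc(-c3ccc(F)cc3)s2)cc1` has not yet been measured. It differs from compound 1 in one place: fluoro in place of methoxy on an aromatic carbon. The change sits on an aromatic carbon of a six-membered aromatic ring of carbon only, para to a large group, and the part that leaves is larger than the part that enters.

Within the data shown here, with no measured step to lean on, the expectation rests on compound 1 alone, whose 267 nM sets the anchor. A modest loss of growth inhibition is expected, close to the edge of the scatter, so the estimate for compound 3 in this assay is 500 nM, with a range from 200 nM to 1500 nM. The step this estimate means is expected to be a 1.9-fold higher number from compound 1 to compound 3 (0.27 log units; within the scatter).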

Compound 3, concentration for 50% growth inhibition: 1560 nM
Compound 3: the middle estimate sits 3.1-fold (0.49 log units) below what was measured; the measured number lies above the stated range.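

In this assay, going by these compounds alone, the change at this place, on an aromatic carbon para to a large group, gives the first measured step, a 5.8-fold higher number from compound 1 to compound 3 (0.77 log units; beyond the scatter) and beyond the scatter, so this position is not indifferent to the group it carries. On this single pair, methoxy goes with stronger inhibition of growth than fluoro, and the change removes one heavy atom as well as the hydrogen-bond acceptor counted for methoxy, so size and acceptor count move together and cannot be told apart here. No measurement at hand bears on why the number rises.

From the compounds shown here alone, whether the trend follows the size of the group or the presence of an oxygen remains open, and a hydroxyl, an ethoxy, a chloro or a methyl group at the same place on the core of compound 1 would separate these readings. Going by these compounds, compound 2 offers no value to set against either compound, so the effect of chloro groups on this ring, and whether the same step holds in any other cell line, stay unknown.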